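A Methyl on the Amide Nitrogen and Solubility

A few compounds are considered here, and "the series" means these few. Any claim that something is new, unique, unknown or untested is made for them only; others in the source may bear on it.

Compound 1 `Cc1cc(OCc2ccc(F)cc2F)c(Br)c(=O)n1-c1cccc(C(N)=O)c1` was measured in a physicochemical assay for solubility; on this read-out lower numbers stand for lower solubility and higher numbers for higher solubility. In this assay compound 1 gives only a limit, < 10 ug/mL. Compound 2 `Cc1cc(OCc2ccc(F)cc2F)c(Br)c(=O)n1-c1c(F)cccc1F` likewise gives only a limit in this assay, < 10 ug/mL. The step that the two limits leave unreadable from compound 1 to compound 2 therefore cannot be read, as the limit of < 10 ug/mL in this assay, at which 2 of the 2 values shown sit, shows. Compound 3 `CNC(=O)c1cccc(-n2c(C)cc(OCc3ccc(F)cc3F)c(Br)c2=O)c1` differs from compound 1 by methyl in place of hydrogen on an amide-type nitrogen. Among the compounds with values here, no measured step bears on this change, so the expected step in this assay is a step that the limit leaves unreadable from compound 1 to compound 3, likely none beyond the scatter. Compound 3 is estimated at 5 ug/mL in this assay, with a range from 1 ug/mL to 20 ug/mL, and most likely again reported only as a limit.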

Compound 3, solubility: < 10 ug/mL
Compound 3 ended at the assay's limit; the forecaster's own chance of this, stated with the estimate: 70%; the middle value is on the limit's open side.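

Compound 1 and compound 3 both end at a limit rather than a number, so no step between them can be read: the limit of < 10 ug/mL in this assay, at which 3 of the 3 values shown sit.

The compounds shown leave open whether methyl in place of hydrogen on an amide-type nitrogen changes solubility at all.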